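The source may hold more compounds than are shown below. What is called first, only, known or untested is meant among the compounds shown, and "the series" means these compounds.

Working notes on the series in a functional assay with Neuronal acetylcholine receptor; alpha3/beta4 (Homo sapiens) as the target; on this read-out lower numbers stand for stronger inhibition and higher numbers for weaker inhibition.

Compound 1 `CC1C(=O)N(c2ccccc2C(=O)OCC2CCCN(CCCc3ccccc3)C2)C(=O)C1C` gives 6000 nM. Compound 2 `CCC1CC(=O)N(c2ccccc2C(=O)OCC2CCCN(CCCc3ccccc3)C2)C1=O` gives 4500 nM, and the step of a 1.3-fold lower number from compound 1 to compound 2 (0.12 log units; within the scatter) stays within the scatter. Compound 3 `O=C(OCC1CCCN(CCCc2ccccc2)C1)c1ccccc1N1C(=O)CC(C2CCCC2)C1=O` gives 1200 nM, the lowest of the three numbers; the steps of a 5.0-fold lower number from compound 1 to compound 3 (0.70 log units; beyond the scatter) and a 3.8-fold lower number from compound 2 to compound 3 (0.57 log units; beyond the scatter) are both beyond the scatter, so compound 3 stands apart from compounds 1 and 2.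

Compound 4 `O=C(OCC1CCCN(CCCc2ccccc2)C1)c1ccccc1C(F)(F)F` is not yet measured. It differs from compound 3 in that (a group of 4 heavy atoms (1 carbon, 3 fluorine; no ring) in place of a group of 12 heavy atoms (9 carbon, 1 nitrogen, 2 oxygen; one five-membered non-aromatic ring of carbon only, one five-membered non-aromatic ring with 1 hetero atom), on an aromatic carbon), the entering group sitting on an aromatic carbon of a six-membered aromatic ring of carbon only, ortho to a large group. Going by the values given here, no measured step removes the whole group at this position; the steps measured so far only vary what hangs on that group. The step from compound 2 to compound 3, a 3.8-fold lower number from compound 2 to compound 3 (0.57 log units; beyond the scatter), shows that a larger attachment at this position went with a lower number, while the small change from compound 1 to compound 2 changed little. The change to compound 4 goes the other way in size, so a higher number than that of compound 3 is expected, likely beyond the scatter: a 5.0-fold higher number from compound 3 to compound 4 (0.70 log units; beyond the scatter). The estimate for compound 4 is 6000 nM, with a range from 1500 nM to 25000 nM.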

Compound 4, half-maximal inhibitory concentration: 3200 nM
Estimate against measurement, compound 4: 1.9-fold (0.27 log units) above; measured number inside the range.
By their numbers in this assay, from the lowest: compound 3; then compounds 4, 2 and 1 (each within the scatter of the next).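

In this assay, going by these compounds alone, trifluoromethyl replaces the entire ring-bearing group on the aromatic carbon, ortho to a large group, and a 2.7-fold higher number from compound 3 to compound 4 (0.43 log units; beyond the scatter) is the first measured step to remove that group rather than vary what hangs on it; the cyclopentyl-bearing group of compound 3 therefore keeps a modest edge over trifluoromethyl. Against the two smaller ring-bearing groups the picture differs: both a 1.4-fold lower number from compound 2 to compound 4 (0.15 log units; within the scatter) and a 1.9-fold lower number from compound 1 to compound 4 (0.27 log units; within the scatter) leave trifluoromethyl, with no ring and no hydrogen-bond acceptors, level with them within the scatter, so among these four compounds the dioxo ring shows an advantage only when it carries cyclopentyl, as in compound 3. Nothing at hand bears on why these groups compare in this way at this position.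

The compounds shown leave open whether a small group of another kind on this aromatic carbon, such as an amine, a carboxylic acid or a methoxy group, would also stay level with trifluoromethyl. They also leave open whether a cyclohexyl or phenyl group on the dioxo ring would extend the step seen with cyclopentyl.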